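Dichlorophenyl for methoxyphenyl on an amide-linked core

This account rests on a few compounds, and the source may have more. Where it says the series, first, only, none or still open, it means among the compounds named here.

Compound 1, `COc1cccc(CCC(=O)Nc2nc3ccccc3c(=O)s2)c1`, gives 621 nM in an assay on mitochondria (strain Sprague-Dawley) for inhibition of Amine oxidase [flavin-containing] B (Rattus norvegicus), read by fluorescence and Amplex Red, with stated times of 30 min and 45 min; on this read-out higher numbers stand for weaker inhibition and lower numbers for stronger inhibition.
Compound 2, `Cc1sc2nc(NC(=O)CCCc3ccccc3)sc(=O)c2c1C`, gives 26.6 nM in this assay.
Compound 3, `O=C(CCCc1ccccc1)Nc1nc2ccc(Br)cc2c(=O)s1`, reaches only a limit of this assay, > 10000 nM.

Among the two numbers that are actual values, compound 1 has the higher one; the nearest measured neighbour, compound 2, sits well beyond the scatter on the stronger side. For compound 3 only a limit is known: the limit of > 10000 nM in this assay, at which 1 of the 3 values shown sits.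

Compound 4, `O=C(CCc1ccc(Cl)c(Cl)c1)Nc1nc2ccccc2c(=O)s1`, is not yet measured. It differs from compound 1 in one place: 3,4-dichlorophenyl in place of 3-methoxyphenyl on a saturated chain carbon, two bonds along the chain from a carbonyl carbon. Among the measured compounds shown here, no measured pair in this set shows the same change, so the expectation rests on compound 1 alone and on the size of swap involved, a similarly sized aromatic ring with halogens in place of an ether oxygen.

From compound 1 to compound 4 a modest step towards stronger inhibition is expected, a 2.1-fold lower number from compound 1 to compound 4 (0.32 log units; beyond the scatter), with a real chance that it stays within the scatter. Compound 4 is therefore estimated at 300 nM, with a plausible range from 60 nM to 1500 nM.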

Compound 4, half-maximal inhibitory concentration: > 10000 nM
Compound 4 gave a limit, no number (the forecaster's own chance of this, stated with the estimate: 5%); middle value at least 33-fold (1.52 log units) from the limit.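

At the saturated chain carbon, two bonds along the chain from a carbonyl carbon, the two groups match in heavy atoms and in their aromatic ring, yet 3,4-dichlorophenyl in place of 3-methoxyphenyl gives an at least 16-fold higher number from compound 1 to compound 4 (1.20 log units; beyond the scatter), a large step towards weaker inhibition. Among the compounds shown here, this is the first change read at this position, and it shows that the inhibition of compound 1 does not survive every aromatic group placed there. Compound 4 gives a limit in this assay, not a number, and it does not stand there alone: the limit of > 10000 nM in this assay, at which 2 of the 4 values shown sit.

From the compounds shown here alone, how far compound 4 lies past that limit stays unknown. Also open, going by these compounds, is whether one chlorine alone, as in 3-chlorophenyl or 4-chlorophenyl, brings the same loss, or whether 3,4-dimethoxyphenyl keeps the inhibition of compound 1.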